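Quaternary ammonium chain variants on a fused core

This account rests on a few compounds, and the source may have more. Where it says the series, first, only, none or still open, it means among the compounds named here.

Measured so far in an assay on LX2 cells for inhibition of COL1A1 promoter (Homo sapiens), read by a luciferase reporter, with a stated time of 24 h, tested at 50 uM; a lower number here means a weaker effect, a higher number a stronger effect of the compound at the concentration tested:
- compound 1, `Cc1ccc(-n2cc(C(=O)Nc3cc(F)cc(F)c3)c(=O)c3ccc(N(C)C)nc32)cc1OCCCCCCC[N+]1(C)CCCC1`, gives 55.9%
- compound 2, `CN(C)c1ccc2c(=O)c(C(=O)Nc3cc(F)cc(F)c3)cn(-c3ccc(Cl)c(OCCCCCCC[N+]4(C)CCCC4)c3)c2n1`, gives 76.1%
- compound 3, `CC[N+]1(CCCCCCCOc2ccc(-n3cc(C(=O)Nc4cc(F)cc(F)c4)c(=O)c4ccc(N(C)C)nc43)cc2Cl)CCCCC1`, gives 50.4%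

Compound 1 stands second highest of the three numbers. Its nearest neighbour is compound 3, whose value lies within the scatter of that of compound 1, so no order between the two is claimed. For the measured compounds named here, the furthest is compound 2, and that step, a number 20.2 percentage points higher from compound 1 to compound 2 (beyond the scatter), is the only single-point change among the measured compounds; it goes with chloro in place of methyl on an aromatic carbon.

Compound 4, `CC[N+]1(CCCCCCCOc2cc(-n3cc(C(=O)Nc4cc(F)cc(F)c4)c(=O)c4ccc(N(C)C)nc43)ccc2C)CCCC1`, differs from compound 1 in one place: methyl in place of hydrogen on a saturated chain carbon bound to an amine nitrogen in a ring. Going by the values given here, no measured step bears on this change. Compound 3 also carries an ethyl on its ring nitrogen, but it differs from compound 1 in several places at once, so its value only shows that it sits within the scatter of compound 1. With nothing pointing either way, the expectation for compound 4 in this assay is a step of no size beyond the scatter, a number 0.1 percentage points higher from compound 1 to compound 4 (within the scatter). The estimate for compound 4 is therefore 56%, expected between 42% and 70%.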

Compound 4, a percentage reported as inhibition, at one concentration (the size of the read-out at that concentration, not a potency): 81.4%
The estimate for compound 4 lay 25.4 percentage points below the measured number; measured number outside the range, above it.
By their numbers in this assay, from the lowest: compounds 3 and 1 (each within the scatter of the next); then compounds 2 and 4 (each within the scatter of the next).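

In this assay, a saturated chain carbon bound to an amine nitrogen in a ring proves to be a position where a small change can register: methyl in place of hydrogen there gives a number 25.5 percentage points higher from compound 1 to compound 4 (beyond the scatter). Read one bond further out, the same difference is methyl to ethyl, and it is the second single-place change from compound 1 to reach beyond the scatter, alongside the aromatic-carbon change of chloro in place of methyl, a number 20.2 percentage points higher from compound 1 to compound 2 (beyond the scatter). No measurement bears on why the added methyl goes with a higher number, so the step stands as an observation from a single pair of compounds.

On these data alone, whether the number continues to rise, levels off or falls when ethyl gives way to propyl, butyl or a benzyl group remains open, as does what a hydroxyethyl group would do at this place. Also open, as far as these compounds go, is whether the step from methyl to ethyl carries over to a piperidine ring or to a core with chloro in place of methyl on the aromatic carbon.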